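The source may hold more compounds than are shown below. What is called first, only, known or untested is meant among the compounds shown, and "the series" means these compounds.

Compound 1 `COc1ccc(S(=O)(=O)N(Cc2cc(F)cc(F)c2)[C@H](C)C(=O)NO)cc1` is the reference point of this small set. In an assay on isolated protein for inhibition of bone morphogenetic protein 1 (Homo sapiens) (a lower number here means a stronger inhibitor, a higher number a weaker inhibitor), compound 1 gives 140 nM. Compound 2 `COc1ccc(S(=O)(=O)N(Cc2cc(C(F)(F)F)cc(C(F)(F)F)c2)[C@H](C)C(=O)NO)cc1` gives 220 nM in this assay; the two values lie within the usual scatter of each other, so the numbers seen so far do not separate them. Compound 3 `COc1ccc(S(=O)(=O)N(Cc2ccc(SC)cc2)[C@H](C)C(=O)NO)cc1` has not yet been measured. It differs from compound 1 in one place: 4-(methylsulfanyl)phenyl in place of 3,5-difluorophenyl on a saturated chain carbon bound to a sulfonamide nitrogen. Within the data shown here, no measured pair shows this change, and the two values at hand give no guide to how a group of this kind on the saturated chain carbon bound to the sulfonamide nitrogen moves the number. The expected step of a 1.4-fold higher number from compound 1 to compound 3 (0.15 log units; within the scatter) is therefore small, with no direction beyond the scatter. Compound 3 is expected to give about 200 nM in this assay, with a range from 70 nM to 600 nM.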

Compound 3, half-maximal inhibitory concentration: 80 nM
Beside the measured number, compound 3's estimate is 2.5-fold (0.40 log units) above it; low and high end bracket the measured number.
By their numbers in this assay, from the lowest: compounds 3, 1 and 2 (each within the scatter of the next, the first and the last beyond it).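

In this assay, the exchange on the saturated chain carbon bound to a sulfonamide nitrogen gives a 1.8-fold lower number from compound 1 to compound 3 (0.24 log units; within the scatter), the first single-place step read at this position, and it does not order the two compounds. The place therefore holds both 3,5-difluorophenyl and 4-(methylsulfanyl)phenyl, groups of equal heavy-atom count that differ in fluorine against sulfur and in hydrogen-bond acceptor count, without the number moving beyond the scatter. Nothing at hand gives a reason for this result.

Open, from the compounds shown here alone, is whether the sulfur matters at all, which a methoxy group in place of the methylsulfanyl group would test. Also open, going by these compounds, is how far the place stays this permissive with an unsubstituted phenyl, or with a phenyl carrying an amine or a carboxylic acid.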